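A few compounds are considered here, and "the series" means these few. Any claim that something is new, unique, unknown or untested is made for them only; others in the source may bear on it.

Working notes on the series built on the shared core of compound 1 `Cn1c(N)c(-c2nc3ccccc3[nH]2)c2nc(C#N)c(C#N)nc21`. In a functional assay on A549 cells (Homo sapiens) for antiproliferative activity, read by MTT assay, with a stated time of 48 h (on this read-out higher numbers stand for weaker inhibition and lower numbers for stronger inhibition), compound 1 gives > 50000 nM, which is a limit of the assay and not a number. Compound 2 `CCN(CC)CCn1c(N)c(-c2nc3ccccc3[nH]2)c2nc(C#N)c(C#N)nc21` carries a 2-(diethylamino)ethyl chain on the aromatic nitrogen; in this assay compound 2 also gives > 50000 nM, again a limit rather than a number. Going by the values given here, compound 3 `CCCn1c(N)c(-c2nc3ccccc3[nH]2)c2nc(C#N)c(C#N)nc21`, with propyl on that nitrogen, gives 1970 nM in this assay and so stands as the only number among the three values shown, the other two sitting at the limit of > 50000 nM in this assay, at which 2 of the 3 values shown sit. The step of an at least 25-fold lower number from compound 1 to compound 3 (1.40 log units; beyond the scatter) is large, as is an at least 25-fold lower number from compound 2 to compound 3 (1.40 log units; beyond the scatter), while the step that the two limits leave unreadable from compound 1 to compound 2 cannot be read from two limits.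

Compound 4 `CCN(CC)CCCn1c(N)c(-c2nc3ccccc3[nH]2)c2nc(C#N)c(C#N)nc21` differs from compound 3 by diethylamino in place of hydrogen on a saturated chain carbon, three bonds along the chain from an aromatic nitrogen. Among the compounds with values here, two measured steps bear on this change: an at least 25-fold lower number from compound 2 to compound 3 (1.40 log units; beyond the scatter), which swaps a diethylamino two bonds along the chain for methyl and lowers the number strongly, and an at least 25-fold lower number from compound 1 to compound 3 (1.40 log units; beyond the scatter), which shows that the bare chain alone carries the gain. The change from compound 3 to compound 4 puts a diethylamino back onto the chain, cut one bond further out, so a sizeable rise in the number is expected, possibly back to a limit. Compound 4 is expected to give about 15000 nM in this assay, within 3000 nM to 60000 nM, an estimated step of a 7.6-fold higher number from compound 3 to compound 4 (0.88 log units; beyond the scatter).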

Compound 4, half-maximal inhibitory concentration: 25300 nM
Compound 4: the middle estimate sits 1.7-fold (0.23 log units) below what was measured; measured number inside the range.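

On the propyl chain, diethylamino in place of hydrogen, three bonds along the chain from an aromatic nitrogen, gives in this assay a clear loss, now readable as a number and not only as a limit: there is a 13-fold higher number from compound 3 to compound 4 (1.11 log units; beyond the scatter), so the gain seen with the bare propyl chain does not survive this change. The steps from the two limit compounds are much less informative, with an at least 1.9-fold lower number from compound 2 to compound 4 (0.29 log units; that floor lies within the scatter) and an at least 1.9-fold lower number from compound 1 to compound 4 (0.29 log units; that floor lies within the scatter), and since both floors lie within the scatter, neither step shows compound 4 to be separated from compound 2 or compound 1 by more than the usual spread. Those two steps stay floors, as the values of compound 1 and compound 2 are limits and not numbers: the limit of > 50000 nM in this assay, at which 2 of the 4 values shown sit.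

From the compounds shown here alone, whether the rise in the number belongs to diethylamino itself or would also follow a dimethylamino group, a morpholine ring or a hydroxyl group, three bonds along the chain from an aromatic nitrogen, stays open. Equally open, going by these compounds, is how the number moves on a longer bare chain such as butyl or pentyl, and whether propyl marks a limit of the gain on this nitrogen.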